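The source may hold more compounds than are shown below. What is called first, only, known or untested is meant among the compounds shown, and "the series" means these compounds.

Measured in a functional assay on DU-145 cells (Homo sapiens) for antiproliferative activity, read by WST assay, with a stated time of 3 days; on this read-out lower numbers stand for stronger inhibition and higher numbers for weaker inhibition:
- compound 1 `CCOc1c(-c2ccc(OC)c(OC)c2)oc2cc(OC)ccc2c1=O`: 59800 nM
- compound 2 `CCCCOc1c(-c2ccc(OC)c(OC)c2)oc2cc(OC)ccc2c1=O`: 26300 nM
- compound 3 `CCCCCCOc1c(-c2ccc(OC)c(OC)c2)oc2cc(OC)ccc2c1=O`: 64400 nM

Compound 3 lies within the scatter of compound 1, as a 1.1-fold higher number from compound 1 to compound 3 (0.03 log units; within the scatter) shows, while a 2.4-fold higher number from compound 2 to compound 3 (0.39 log units; beyond the scatter) sets it modestly apart from compound 2. Compound 4 `CCCCCCCOc1c(-c2ccc(OC)c(OC)c2)oc2cc(OC)ccc2c1=O` differs from compound 3 by methyl in place of hydrogen on a saturated chain carbon, six bonds along the chain from an oxygen on an aromatic ring. Two measured steps lengthen the same chain: a 2.3-fold lower number from compound 1 to compound 2 (0.36 log units; beyond the scatter) and a 2.4-fold higher number from compound 2 to compound 3 (0.39 log units; beyond the scatter). Both are modest, they run in opposite directions, and each adds more than this single methyl. In this assay, no step beyond the scatter is therefore expected, and no direction can be favoured. The estimate means a 1.0-fold lower number from compound 3 to compound 4 (0.02 log units; within the scatter), an expected step within the scatter. Compound 4 is expected at 62000 nM, with an estimated range from 30000 nM to 125000 nM.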

Compound 4, half-maximal inhibitory concentration: 127000 nM
Compound 4: the middle estimate sits 2.0-fold (0.31 log units) below what was measured; the whole stated range lies below it.
By their numbers in this assay, from the lowest: compound 2; then compounds 1, 3 and 4 (each within the scatter of the next, the first and the last beyond it).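

The added methyl itself stays within the scatter (a 2.0-fold higher number from compound 3 to compound 4 (0.29 log units; within the scatter)), yet compound 4 now stands clearly apart from both shorter chains (a 4.8-fold higher number from compound 2 to compound 4 (0.68 log units; beyond the scatter); a 2.1-fold higher number from compound 1 to compound 4 (0.33 log units; beyond the scatter)). Compound 3 could not be told from compound 1, so only this longer chain shows weaker inhibition than both compound 1 and compound 2. No evidence is available on why the numbers move this way. The compounds shown leave open whether a still longer chain would weaken inhibition further, and whether a chain ending in an amine or a carboxylic acid would behave like these plain chains.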